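Naphthalenyl Sulfonamide Compared with Trifluoromethylphenyl Parent

This account rests on a few compounds, and the source may have more. Where it says the series, first, only, none or still open, it means among the compounds named here.

Measured compounds:
compound 1 `O=C(NCc1ccc(CNS(=O)(=O)c2cccc(C(F)(F)F)c2)cc1)c1ccc(F)cc1`: 100 nM
compound 2 `O=C(NCc1ccc(CNS(=O)(=O)c2cccc(Cl)c2)cc1)c1ccc(F)cc1`: 1 nM
compound 3 `O=C(NCc1ccc(CNS(=O)(=O)c2cccnc2)cc1)c1ccc(F)cc1`: 1000 nM

All three were tested in an assay on MDA-MB-231 cells for binding affinity to C-X-C chemokine receptor type 4 (Homo sapiens), read by fluorescence and microscopy, with stated times of 10 min and 30 min; a higher number here means that more compound is needed for the effect, a lower number that less compound is needed. Compound 1 stands second highest of the three numbers. The nearest neighbour is a 10-fold higher number from compound 1 to compound 3 (1.00 log units; beyond the scatter), the furthest is a 100-fold lower number from compound 1 to compound 2 (2.00 log units; beyond the scatter). Every measured step is beyond the scatter, and the whole spread is set by what sits on the sulfonyl sulfur, while the rest of the shared core is unchanged.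

Compound 4 `O=C(NCc1ccc(CNS(=O)(=O)c2cccc3ccccc23)cc1)c1ccc(F)cc1` carries the change (naphthalen-1-yl in place of 3-(trifluoromethyl)phenyl on a sulfonyl sulfur). For the measured compounds named here, no measured step puts a naphthalen-1-yl group in this position, so nothing bears on it directly. The steps that also exchange the group on the sulfonyl sulfur are the closest in kind: a 10-fold higher number from compound 1 to compound 3 (1.00 log units; beyond the scatter) and a 1000-fold higher number from compound 2 to compound 3 (3.00 log units; beyond the scatter), both large, and they show that this position can move the number strongly in either direction. Going by the values given here, compound 4 keeps an all-carbon aromatic group, as compounds 1 and 2 do, and compound 3, the only one with a different ring, gave the highest number.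

Among the compounds with values here, compound 4 is therefore expected to give 30 nM, within 3 nM to 300 nM, an estimated 3.3-fold lower number from compound 1 to compound 4 (0.52 log units; beyond the scatter), with the wide range reflecting that no measured step resembles this change.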

Compound 4, effective concentration (reported as EC, without a stated level of effect): 1000 nM
Beside the measured number, compound 4's estimate is 33-fold (1.52 log units) below it, and the stated range ends below it.
By their numbers in this assay, from the lowest: compound 2; then compound 1; then compounds 3 and 4 (each within the scatter of the next).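

In this assay, for the compounds shown here, an all-carbon aromatic group on the sulfonyl sulfur does not by itself keep the number low, as the earlier compounds might have suggested. Naphthalen-1-yl gives a clear loss against both phenyl-based groups (a 10-fold higher number from compound 1 to compound 4 (1.00 log units; beyond the scatter); a 1000-fold higher number from compound 2 to compound 4 (3.00 log units; beyond the scatter)), so compound 4 now goes against any link between the highest number and the pyridin-3-yl ring of compound 3. The two groups also cannot be told apart here despite their different rings (no change at the digits printed from compound 3 to compound 4 (within the scatter)), and nothing shown explains why the second six-membered ring of carbon in naphthalen-1-yl costs so much.

From the compounds shown here alone, it remains open whether the loss comes from the second ring as such or from the way it is attached, which naphthalen-2-yl on the sulfonyl sulfur could help to separate. Also open, going by these compounds, is how the number would respond if a single phenyl ring carried an amine, a carboxylic acid or a methoxy group in place of the chloro of compound 2.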